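Bromo Added to a Hydroxyamino Core: Expected Cytotoxicity

The source may report more compounds than this note shows. Statements on the series, on what has been measured and on what is new or still open speak of the compounds shown alone.

Compound 1 `CCNc1ncnc2c1c(Br)cn2COC(CO)CO`: in an ADME assay on HFF cells (Homo sapiens) for cytotoxicity (on this read-out higher numbers stand for weaker inhibition and lower numbers for stronger inhibition), compound 1 gives > 100000 nM, which is a limit of the assay.
Compound 2 `OCC(CO)OCn1ccc2c(NO)ncnc21`: compound 2 gives > 100000 nM, also a limit.
Compound 3 `OCC(CO)OCn1ccc2cncnc21`: compound 3 gives > 100000 nM, also a limit.

Compound 2 therefore stands only at an assay limit, as do all the values shown (the limit of > 100000 nM in this assay, at which 3 of the 3 values shown sit). Compound 4 `OCC(CO)OCn1cc(Br)c2c(NO)ncnc21` differs from compound 2 by bromo in place of hydrogen on an aromatic carbon. Within the data shown here, the only measured step, a step that the two limits leave unreadable from compound 2 to compound 3, has both ends at the limit and gives no readable size. Compound 1, which also carries a bromo group, sits at the same limit. In this assay the step that the limit leaves unreadable from compound 2 to compound 4 is therefore expected to stay within the scatter, in no clear direction. Compound 4 is estimated at 150000 nM, with a range from 50000 nM to 500000 nM, and is most likely to be reported again only as a limit.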

Compound 4, half-maximal inhibitory concentration: > 100000 nM
Compound 4 was reported as a limit (the forecaster's own chance of this, stated with the estimate: 85%); the middle value does not contradict the limit.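

Among these compounds, no step from compound 2 or compound 1 to compound 4 can be read, because every value stands at one limit: the limit of > 100000 nM in this assay, at which 4 of the 4 values shown sit. The compounds shown leave open whether bromo, or any other change among them, alters the result in this assay at all.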